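Methoxy on the anilino group of compound 2

The source may hold more compounds than are shown below. What is called first, only, known or untested is meant among the compounds shown, and "the series" means these compounds.

In a functional assay on FM3A cells (Mus musculus) for antiproliferative activity, read by cell counting, with a stated time of 2 days (on this read-out lower numbers stand for stronger inhibition and higher numbers for weaker inhibition), compound 1 (`COc1cc(C(=O)c2sc(Nc3ccccc3)nc2N)cc(OC)c1OC`) gives 23 nM. Compound 2 (`COc1ccc(C(=O)c2sc(Nc3ccccc3)nc2N)cc1OC`) stands at > 10000 nM, which is a limit of the assay and not a number. Compound 4 (`COc1ccc(Nc2nc(N)c(C(=O)c3ccc(OC)c(OC)c3)s2)cc1`) differs from compound 2 by methoxy in place of hydrogen on an aromatic carbon, with anilino becoming (4-methoxyphenyl)amino.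

For the measured compounds named here, the only measured step of this type is an at least 430-fold higher number from compound 1 to compound 2 (2.63 log units; beyond the scatter), large and beyond the scatter. That step removes a methoxy elsewhere in the molecule, so it shows the size such a swap can reach, not the direction expected here. Compound 3 (`COc1ccc(Nc2nc(N)c(C(=O)c3ccc(Cl)cc3)s2)cc1`) carries the same (4-methoxyphenyl)amino group as compound 4, and in this assay compound 3 gives 59 nM, so that group is compatible with a low number. A lower number than the limit is therefore expected, although compound 4 could stay at the limit. The expected size is an at least 6.6-fold lower number from compound 2 to compound 4 (0.82 log units; beyond the scatter). For compound 4 the estimated value is 1500 nM, with an expected range of 150 nM to 10000 nM.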

Compound 4, half-maximal inhibitory concentration: 71 nM
Beside the measured number, compound 4's estimate is 21-fold (1.32 log units) above it, and the stated range ends above it.
By their numbers in this assay, from the lowest: compound 1; then compounds 3 and 4 (each within the scatter of the next). At a limit, above all of these: compound 2.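

In this assay, the change from anilino to (4-methoxyphenyl)amino gives an at least 140-fold lower number from compound 2 to compound 4 (2.14 log units; beyond the scatter), so a single methoxy at this place, para to a large group, is enough to take the series from a limit to a low number. For the compounds shown here, the earlier compounds showed only that this group was compatible with a low number, in compound 3, which has a different carbonyl substituent; the present pair isolates the change at this position. The size of the step is itself only a lower bound, because compound 2 sits at a limit: the limit of > 10000 nM in this assay, at which 1 of the 4 values shown sits.

The compounds shown hold only hydrogen and methoxy at this place, so the outcome with a hydroxyl, an amine or an ethoxy there remains open. Also open, on these data alone, is whether the same methoxy changes the number when added to compound 1, which already gives a low value.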